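The compounds below may be only part of what the source reports. "The series", "measured", "known", "first", "only" and "open" are said of these compounds alone.

Compound 1 `O=C(CCCCCCc1ccccc1)c1nc(-c2ccccn2)co1` and compound 2 `O=C(CCCCCCc1ccccc1)c1nc(-c2ccncc2)co1` share one core and differ only in the pyridin-2-yl of compound 1 against the pyridin-4-yl of compound 2. In an assay on isolated protein for inhibition of neutral cholesterol ester hydrolase 1 (Homo sapiens) (on this read-out lower numbers stand for stronger inhibition and higher numbers for weaker inhibition), compound 1 gives > 100000 nM, which is a limit of the assay rather than a number. In this assay compound 2 likewise gives > 100000 nM, again a limit. Within the data shown here, the one measured step, a step that the two limits leave unreadable from compound 1 to compound 2, therefore cannot be sized, because both values sit at the limit of > 100000 nM in this assay, at which 2 of the 2 values shown sit. Compound 2 thus stands at the limit, and nothing shown separates it from compound 1.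

Compound 3 `O=C(CCCCCCc1ccccc1)c1nc(C(F)(F)F)co1` is the unmeasured compound; it differs from compound 2 by trifluoromethyl in place of pyridin-4-yl on an aromatic carbon. Among the measured compounds shown here, no measured step reads on this exchange, since the only step in hand is itself unreadable. What is known is merely that both aromatic groups tried on the core leave the value at the limit. Compound 3 is therefore expected to remain weak in this assay, with an estimated step of a number no higher from compound 2 to compound 3 (the limit leaves the size open) and an estimated value of 100000 nM, from 30000 nM to 300000 nM.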

Compound 3, half-maximal inhibitory concentration: 10000 nM
Estimate against measurement, compound 3: 10-fold (1.00 log units) above; measured number outside the range, below it.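

This position on the shared core turns out to matter: in this assay, trifluoromethyl in place of pyridin-4-yl gives an at least 10-fold lower number from compound 2 to compound 3 (1.00 log units; beyond the scatter), and trifluoromethyl in place of pyridin-2-yl gives an at least 10-fold lower number from compound 1 to compound 3 (1.00 log units; beyond the scatter). Among these compounds, the two pyridine compounds could not be told apart, whereas compound 3 gives the first real number, so the group on this aromatic carbon, next to the ring nitrogen, can shift the read-out beyond the usual scatter. Both steps give only the smallest possible size of the change, because their starting points are limits and not numbers: the limit of > 100000 nM in this assay, at which 2 of the 3 values shown sit.

The exchange changes several things at once, since the entering group has no ring, fewer heavy atoms than pyridin-4-yl and no hydrogen-bond acceptor, and the compounds shown cannot say which of these differences counts. Also open, on these data alone, is how a methyl, a plain phenyl ring or a nitrile on this same carbon would compare with the trifluoromethyl of compound 3.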